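Replacing the ester chain on the enamine nitrogen of compound 1

This account rests on a few compounds, and the source may have more. Where it says the series, first, only, none or still open, it means among the compounds named here.

Compound 1 `Cc1cn([C@@H]2O[C@H](CO[Si](C)(C)C(C)(C)C)[C@@]3(OS(=O)(=O)C=C3NCCC(=O)OCc3ccccc3)[C@H]2O[Si](C)(C)C(C)(C)C)c(=O)n(C)c1=O` serves as the reference of this small set. In a functional assay on MT4 cells (Homo sapiens) (on this read-out higher numbers stand for lower toxicity in this test and lower numbers for higher toxicity in this test), compound 1 reaches only a limit, > 250000 nM, so its position is known as a bound and not as a number, in keeping with the limit of > 250000 nM in this assay, at which 1 of the 2 values shown sits. Compound 2 `COC(=O)CNC1=CS(=O)(=O)O[C@@]12[C@@H](CO[Si](C)(C)C(C)(C)C)O[C@@H](n1cc(C)c(=O)n(C)c1=O)[C@@H]2O[Si](C)(C)C(C)(C)C` carries methoxycarbonyl in place of (benzyloxycarbonyl)methyl on a saturated chain carbon bound to an amine nitrogen, and in this assay compound 2 gives 105000 nM; the step is an at least 2.3-fold lower number from compound 1 to compound 2 (0.37 log units; beyond the scatter).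

Compound 3 `C=C(C)C(=O)NC(=O)NC1=CS(=O)(=O)O[C@@]12[C@@H](CO[Si](C)(C)C(C)(C)C)O[C@@H](n1cc(C)c(=O)n(C)c1=O)[C@@H]2O[Si](C)(C)C(C)(C)C` changes the same nitrogen: ((1-methylethenyl)carbonyl)carbamoyl in place of 2-(benzyloxycarbonyl)ethyl on an amine nitrogen. Among the compounds with values here, the one measured step, from compound 1 to compound 2, also altered the substituent on that nitrogen and lowered the number, so it bears on the new change, though the entering group here is of a different kind. A shift of comparable size is therefore taken as the working expectation, with a lowering beyond the scatter plausible but not assured. For compound 3 the expected step is an at least 1.6-fold lower number from compound 1 to compound 3 (0.22 log units; that floor lies within the scatter). Compound 3 is estimated at 150000 nM, within 50000 nM to 300000 nM, and a reading that again stops at the limit remains a real possibility.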

Compound 3, half-maximal cytotoxic concentration: 1190 nM
Compound 3: middle estimate off by 130-fold (2.10 log units), on the high side; measured number outside the range, below it.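

Notes on the amine nitrogen on the double-bonded ring carbon: this position tolerates far larger shifts than the earlier pair showed, and in this assay placing ((1-methylethenyl)carbonyl)carbamoyl there gives an at least 210-fold lower number from compound 1 to compound 3 (2.32 log units; beyond the scatter). The comparison with compound 2 rests on two actual numbers and gives an 88-fold lower number from compound 2 to compound 3 (1.95 log units; beyond the scatter), so the large lowering does not depend on a bound, and compound 3 has the lowest number of the three, meaning the highest toxicity in this test. Compound 1 remains a limit and not a number, so any step from it is a floor only: the limit of > 250000 nM in this assay, at which 1 of the 3 values shown sits.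

The compounds shown leave open whether the lowering goes with the terminal 1-methylethenyl group or with the carbonyl-carbamoyl link, which a saturated 2-methylpropanoyl carbamoyl group or a plain carbamoyl group on the same nitrogen would separate. Also open, from the compounds shown here alone, is whether the same step would appear on the core with free hydroxyl groups in place of the tert-butyldimethylsilyl ethers.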